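This account rests on a few compounds, and the source may have more. Where it says the series, first, only, none or still open, it means among the compounds named here.

Compound 1 `CC[C@@H]1C(=O)N(C)c2cnc(Nc3ccc(S(=O)(=O)NC)cc3)nc2N1C1CCCC1`: 222 nM
Compound 2 `CCCNS(=O)(=O)c1ccc(Nc2ncc3c(n2)N(C2CCCC2)[C@H](CC)C(=O)N3C)cc1`: 548 nM
Compound 3 `CCCCNC(=O)c1ccc2c(ccn2-c2ncc3c(n2)N(c2ccn(C)n2)C(CC)C(=O)N3C)c1`: 14100 nM

In a functional assay on K562 cells (Homo sapiens) for antiproliferative activity, read by CCK-8 assay, with a stated time of 72 h (a lower number here means a stronger inhibitor of growth, a higher number a weaker inhibitor of growth), compound 1 gives 222 nM, while compound 2 gives 548 nM. The two share a core and differ in one place, (hydrogen in place of ethyl on a saturated chain carbon bound to a sulfonamide nitrogen). This change made a modest step, a 2.5-fold lower number from compound 2 to compound 1 (0.39 log units; beyond the scatter). Compound 3 sits on a different core; the difference between the two cores is not broken down here. In this assay compound 3 gives 14100 nM, the highest number of the three, far beyond the scatter from compound 2 and further still from compound 1.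

Compound 4 `CCNC(=O)c1ccc2c(ccn2-c2ncc3c(n2)N(c2ccn(C)n2)C(CC)C(=O)N3C)c1` is not yet measured. It differs from compound 3 in one place, (hydrogen in place of ethyl on a saturated chain carbon, two bonds along the chain from an amide-type nitrogen). This is the same kind of change as that from compound 2 to compound 1, though at a different place: there the carbon is bound to a sulfonamide nitrogen, here it lies two bonds along the chain from an amide-type nitrogen. Because a 2.5-fold lower number from compound 2 to compound 1 (0.39 log units; beyond the scatter) was modest and the place is not identical, only a small step is expected, a 1.6-fold lower number from compound 3 to compound 4 (0.19 log units; within the scatter). For compound 4 the estimate in this assay is 9000 nM, between 3500 nM and 25000 nM.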

Compound 4, concentration for 50% growth inhibition: 12800 nM
For compound 4 the middle estimate is 1.4-fold (0.15 log units) below the measured one; low and high end bracket the measured number.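

In this assay, putting hydrogen in place of ethyl on the saturated chain, which turns the butylamino group of compound 3 into the ethylamino group of compound 4, gives a 1.1-fold lower number from compound 3 to compound 4 (0.04 log units; within the scatter). Set beside the earlier step, this result gives no sign that the change reads differently on the two cores: the same change on two cores in this assay, a 2.5-fold lower number (0.39 log units; beyond the scatter) from compound 2 to compound 1 and a 1.1-fold lower number (0.04 log units; within the scatter) from compound 3 to compound 4, 2.2-fold (0.35 log units) apart, within the scatter of two such steps. Among these compounds, it does not show that the change carries over as a rule, for there is only one pair on each core, the place on the chain is not the same, and only the earlier step lies beyond the scatter.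

The compounds shown leave open how a longer chain, a cyclopropyl group, an amine or a carboxylic acid at this place would read on either core. They also leave open whether a methyl group on the amide nitrogen of compound 4 would read as the methyl group on the sulfonamide nitrogen of compound 1 does.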